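Adding Trifluoromethyl to Compound 2

A few compounds are considered here, and "the series" means these few. Any claim that something is new, unique, unknown or untested is made for them only; others in the source may bear on it.

In a functional assay, read by spectrophotometry, with a stated time of 2 h (on this read-out higher numbers stand for weaker inhibition and lower numbers for stronger inhibition), compound 1 (`CCOC(=O)N1CCC(=NNC(=O)c2ccc(C)cc2)CC1`) gives 75500 nM and compound 2 (`O=C(NN=C1CC(c2ccccc2)NC(c2ccccc2)C1)c1ccccc1`) gives 42000 nM so far. These two values lie within the usual scatter of repeated measurements, so compound 2 cannot be ranked against compound 1 on these numbers.

Compound 3 (`O=C(NN=C1CC(c2ccccc2)NC(c2ccccc2)C1)c1ccc(C(F)(F)F)cc1`) has not yet been measured. It differs from compound 2 by a single change (trifluoromethyl in place of hydrogen on an aromatic carbon) with trifluoromethyl in place of hydrogen on an aromatic carbon, para to a large group. Put another way, phenyl becomes 4-(trifluoromethyl)phenyl.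

Going by the values given here, no two measured compounds differ in just one place, so the data offer no direct guide to the effect of this change. The value of compound 2 at 42000 nM is therefore the natural starting point, and only a modest shift is expected. The expected step is a 1.4-fold lower number from compound 2 to compound 3 (0.15 log units; within the scatter) and it would point toward slightly stronger inhibition while staying within the scatter. In this assay the estimated value for compound 3 is 30000 nM with an expected range from 10000 nM to 90000 nM in repeat measurements.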

Compound 3, half-maximal inhibitory concentration: 65000 nM
For compound 3 the middle estimate is 2.2-fold (0.34 log units) below the measured one; measured number inside the range.
By their numbers in this assay, from the lowest: compounds 2, 3 and 1 (each within the scatter of the next).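

Going by these compounds alone, the swap of hydrogen for trifluoromethyl on an aromatic carbon, para to a large group, gives the first direct reading of a single change: in this assay it gives a 1.5-fold higher number from compound 2 to compound 3 (0.19 log units; within the scatter) and so cannot be told apart from repeat-measurement noise. This place on the ring therefore accepts a group of four heavy atoms, with one carbon and three fluorines, without any shift that these numbers can resolve, so compound 2 and compound 3 stand level on present data. No accompanying measurement bears on this result, so the numbers alone offer no explanation for it.

The compounds shown leave open whether a different group at this same place, such as an amine, a carboxylic acid or a longer carbon chain, would produce a step beyond the scatter. As far as these compounds go, it also remains open whether trifluoromethyl in place of hydrogen would read the same way on another core, such as the core of compound 1, where this single change has no reading yet.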